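The source may report more compounds than this note shows. Statements on the series, on what has been measured and on what is new or still open speak of the compounds shown alone.

Within the data shown here, in a functional assay on A549 cells (Homo sapiens) for cytotoxicity, read by MTT assay, with a stated time of 72 h (on this read-out lower numbers stand for stronger inhibition and higher numbers for weaker inhibition), compound 1 `COc1ccc(/C=C/C(=O)Nc2cc3c(Nc4ccc(F)c(Cl)c4)ncnc3cc2O[C@H]2CCOC2)c(OC)c1` gives 9350 nM and holds the lower of the two numbers so far. Among the measured compounds shown here, compound 2 `COc1ccc(/C=C/C(=O)Nc2cc3c(Nc4ccc(F)c(Cl)c4)ncnc3cc2OC)c(OC)c1` gives 33300 nM with a 3.6-fold higher number from compound 1 to compound 2 (0.55 log units; beyond the scatter) as the only measured step. Compound 3 `O=C(/C=C/c1ccccc1[N+](=O)[O-])Nc1cc2c(Nc3ccc(F)c(Cl)c3)ncnc2cc1O[C@H]1CCOC1` carries 2-nitrophenyl in place of 2,4-dimethoxyphenyl on a double-bonded chain carbon bound to a double-bonded chain carbon on a double-bonded chain carbon bound to a double-bonded chain carbon. The measured step lies at another place and does not size this change, so no direction is expected in this assay here. The expected step of a 1.1-fold higher number from compound 1 to compound 3 (0.03 log units; within the scatter) stays within the scatter. For compound 3 the estimate is 10000 nM with an expected range from 3500 nM to 30000 nM for now.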

Compound 3, half-maximal inhibitory concentration: 8820 nM
The estimate for compound 3 lay 1.1-fold (0.05 log units) above the measured number; the measured number falls inside the stated range.
By their numbers in this assay, from the lowest: compounds 3 and 1 (each within the scatter of the next); then compound 2.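

In this assay, 2-nitrophenyl in place of 2,4-dimethoxyphenyl on a double-bonded chain carbon bound to a double-bonded chain carbon gives a 1.1-fold lower number from compound 1 to compound 3 (0.03 log units; within the scatter). Among these compounds, this is the first reading at this position, and here an exchange of the whole aromatic substituent leaves the number within the scatter. No measurement on hand bears on why the two groups read alike. Still open, on these data alone, is whether an amine or a carboxylic acid in place of the nitro group would read the same, and whether methyl in place of oxolan-3-yl gives a comparable step with 2-nitrophenyl present.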